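The compounds below may be only part of what the source reports. "The series", "measured", "known", "first", "only" and "open" are said of these compounds alone.

In a functional assay on PC-3 cells (Homo sapiens) for cytotoxicity, read by MTT assay, with a stated time of 48 h, tested at 5 uM (a higher number here means a stronger effect of the compound at the concentration tested, a lower number a weaker effect), the measured compounds gave these numbers:
compound 1 `O=C(c1ccc(O)cc1O)[C@H]1[C@H](c2ccccc2)[C@H](C(=O)c2ccc(O)cc2O)[C@@H]1c1ccccc1`: 12.3%
compound 2 `O=C(c1ccc(O)cc1O)[C@@H]1[C@@H](C(=O)c2ccc(O)cc2O)[C@H](c2ccccc2)[C@@H]1c1ccccc1`: 29%
compound 3 `O=C(c1ccc(O)cc1O)[C@H]1[C@H](c2ccccc2)[C@@H](C(=O)c2ccc(O)cc2O)[C@@H]1c1ccccc1`: 12.8%

All three share the same atoms and bonds and differ only in configuration. Among them compound 2 stands highest in this assay; its nearest neighbour is compound 3 and its furthest is compound 1, both lower by more than the usual scatter. Compound 4 `O=C(c1ccc(O)cc1O)[C@@H]1[C@@H](C(=O)c2ccc(O)cc2O)[C@H](c2ccccc2)[C@H]1c1ccccc1` is the next variation: the two compounds have the same atoms and bonds and differ only in configuration as drawn: 1 of 4 stereo elements differ; a stereocentre at a saturated ring carbon is drawn S in compound 2 and R in compound 4. For the measured compounds named here, the one measured step that changes configuration alone is a number 0.5 percentage points higher from compound 1 to compound 3 (within the scatter), which came out flat (the fact that compounds 1 and 3 differ only in the configuration as drawn). That points to a small step here, yet the gap between compound 2 and the other two shows configuration can matter. Compound 4 is therefore expected to lose a little, a number 7 percentage points lower from compound 2 to compound 4 (within the scatter), and is estimated at 22%, within 8% to 38%.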

Compound 4, a percentage reported as activity, at one concentration (the size of the read-out at that concentration, not a potency): 41.2%
Estimate against measurement, compound 4: 19.2 percentage points below; measured number above the stated range.
By their numbers in this assay, from the lowest: compounds 1 and 3 (each within the scatter of the next); then compound 2; then compound 4.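

In this assay, a change at one stereocentre at a saturated ring carbon gives a step beyond the scatter (a number 12.2 percentage points higher from compound 2 to compound 4 (beyond the scatter)). The earlier pair differed at three stereo elements yet stayed within the scatter (a number 0.5 percentage points higher from compound 1 to compound 3 (within the scatter)), so in these two pairs, more changed stereo elements did not mean a larger step. Only configuration separates the new pair: the fact that compounds 2 and 4 differ only in the configuration as drawn.

All compounds shown carry the same groups on the shared core. On these data alone, whether this configuration step would persist with an amine or a carboxylic acid in place of a phenyl group remains open.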